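The compounds below may be only part of what the source reports. "The series", "measured", "known", "first", "only" and "open" are said of these compounds alone.

Measured so far:

- Compound 1, `CN(C)c1ccc(C(=O)N2CCC(NS(=O)(=O)c3cc(S(=O)(=O)c4ccccc4)ccc3C(F)(F)F)CC2)cc1`, which in an assay on U2OS cells for inhibition of secreted frizzled-related protein 1 (Homo sapiens), read by a luciferase reporter, with a stated time of 18 h (on this read-out lower numbers stand for an effect already at smaller amounts and higher numbers for an effect only at larger amounts of compound), gives 190 nM.
- Compound 2, `O=C(c1cccnc1)N1CCC(NS(=O)(=O)c2cc(S(=O)(=O)c3ccccc3)ccc2C(F)(F)F)CC1`, which in this assay gives 120 nM.
- Compound 3, `O=C(c1ccc(Cl)nc1)N1CCC(NS(=O)(=O)c2cc(S(=O)(=O)c3ccccc3)ccc2C(F)(F)F)CC1`, which in this assay gives 140 nM.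

Compound 3 holds the second highest of these three numbers, but all three sit close together: the smallest gap is a 1.2-fold higher number from compound 2 to compound 3 (0.07 log units; within the scatter) and the largest is a 1.4-fold lower number from compound 1 to compound 3 (0.13 log units; within the scatter), both within the scatter. Compound 4, `O=S(=O)(NC1CCN(S(=O)(=O)c2ccccc2)CC1)c1cc(S(=O)(=O)c2ccccc2)ccc1C(F)(F)F`, is not yet measured. It differs from compound 3 in one place: phenylsulfonyl in place of (6-chloropyridin-3-yl)carbonyl on an amine nitrogen in a ring. The measured steps all concern swapping the aromatic group that sits on the carbonyl, and each of them, a 1.6-fold lower number from compound 1 to compound 2 (0.20 log units; within the scatter), a 1.4-fold lower number from compound 1 to compound 3 (0.13 log units; within the scatter) and a 1.2-fold higher number from compound 2 to compound 3 (0.07 log units; within the scatter), stayed within the scatter. None of them exchanges the carbonyl itself for a sulfonyl, so they bear on the new step only loosely, showing that this end of the molecule has so far tolerated change. The expectation for compound 4 is therefore a step of about a 1.6-fold higher number from compound 3 to compound 4 (0.20 log units; within the scatter) in this assay, with wide uncertainty. Compound 4 is estimated at 220 nM, between 60 nM and 900 nM.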

Compound 4, half-maximal effective concentration: 210 nM
Compound 4: the middle estimate sits 1.0-fold (0.02 log units) above what was measured; the measured number falls inside the stated range.
By their numbers in this assay, from the lowest: compounds 2, 3, 1 and 4 (each within the scatter of the next).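

Until now only the aromatic group on the carbonyl had varied, whereas compound 4 also exchanges the carbonyl for a sulfonyl on the ring nitrogen. In this assay, this wider change still stays within the scatter against all three earlier compounds (a 1.5-fold higher number from compound 3 to compound 4 (0.18 log units; within the scatter); a 1.8-fold higher number from compound 2 to compound 4 (0.24 log units; within the scatter); a 1.1-fold higher number from compound 1 to compound 4 (0.04 log units; within the scatter)), so the link itself, like the aromatic group, can differ here without a readable change in the number. No evidence is available on what lies behind this tolerance.

The compounds shown leave open whether this nitrogen also accepts a group with no aromatic ring, such as a plain methyl, a longer alkyl chain or one ending in a carboxylic acid. On these data alone, it also remains open how a sulfonyl carrying a pyridine ring would compare with compound 4.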